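The compounds below may be only part of what the source reports. "The series", "measured", "known", "first", "only" and "open" are said of these compounds alone.

Measured compounds:
Compound 1, `Cc1nn2c(C(C)c3ccc(CC(C)C)cc3)nnc2s1`: 58%
Compound 2, `CC(C)Cc1ccc(C(C)c2nnc3sc(-c4ccccc4Cl)nn23)cc1`: 59%

In a functional assay on the whole organism (strain Wistar albino) for inhibition, with Rattus norvegicus as the target, read by paw edema, with stated times of 30 min and 2 h, at a dose of 20 mg/kg by the oral route (on this read-out higher numbers stand for more inhibition at the one dose given (going by the name of the read-out) and lower numbers for less inhibition), compound 1 gives 58% and compound 2 gives 59%. Within the data shown here, compound 2 stands at the top of the two numbers, but the only step recorded, a number 1 percentage points higher from compound 1 to compound 2 (within the scatter), does not separate the two compounds, so they read as equal.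

The next compound, compound 3 `CC(C)Cc1ccc(C(C)c2nnc3sc(-c4ccco4)nn23)cc1`, is built from compound 2 by a change at the same position that distinguishes compound 1 from compound 2: furan-2-yl in place of 2-chlorophenyl on an aromatic carbon. Among the measured compounds shown here, the one measured step that bears on this position is the step from compound 1 to compound 2, in which the group on that aromatic carbon grew from methyl to 2-chlorophenyl, and it was a number 1 percentage points higher from compound 1 to compound 2 (within the scatter). Since swapping a small group for a large aromatic group at this carbon left the paw edema read-out unchanged, a swap between two aromatic groups there is expected to move it no further than the scatter. The step from compound 2 to compound 3 is therefore estimated as a number 2 percentage points lower from compound 2 to compound 3 (within the scatter). Compound 3 is accordingly expected to give about 57%, somewhere between 46% and 68%.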

Compound 3, a percentage reported as inhibition, in the whole organism at one dose (the size of the read-out at that dose, not a potency): 59%
Beside the measured number, compound 3's estimate is 2 percentage points below it; measured number inside the range.
By their numbers in this assay, from the lowest: compounds 1, 2 and 3 (each within the scatter of the next).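

Up to this point the position on an aromatic carbon of the five-membered aromatic ring with 2 nitrogen and 1 sulfur had been seen only with methyl and 2-chlorophenyl; exchanging the six-membered aromatic ring of carbon for furan-2-yl, a five-membered aromatic ring with 1 hetero atom and 1 hydrogen-bond acceptor, gives no change at the digits printed from compound 2 to compound 3 (within the scatter) in this assay. Set against the methyl group, furan-2-yl gives a number 1 percentage points higher from compound 1 to compound 3 (within the scatter), so a small group and two different aromatic rings at this carbon all read as equal on this paw edema measure, and the added hetero atom and hydrogen-bond acceptor bring no visible difference. No measurement is at hand that would explain why the read-out stays level across these three groups.

On these data alone, whether an amine, a carboxylic acid or a longer alkyl chain on this carbon would also leave the read-out level remains open. All three numbers come from a single dose, so they also leave open whether the compounds would separate at other doses.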